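Alkenyl change from compound 3 to compound 4

This account rests on a few compounds, and the source may have more. Where it says the series, first, only, none or still open, it means among the compounds named here.

Measured in a functional assay on A549 cells (Homo sapiens) for antiproliferative activity, read by WST assay, with a stated time of 120 h; a higher number here means a weaker inhibitor, a lower number a stronger inhibitor:
- compound 1 `CCC[C@H]1C[C@@H](OC)C/C(C)=C\[C@@H]2C[C@@H](OC(=O)c3ccccc3CCc3coc(/C=C\CNC(=O)OC)n3)C[C@H](CC(=O)O1)O2`: 500 nM
- compound 2 `CCC[C@H]1C[C@@H](OC)C/C(C)=C\[C@@H]2C[C@@H](OC(=O)/C=C\CCc3coc(/C=C\CNC(=O)OC)n3)C[C@H](CC(=O)O1)O2`: 0.5 nM
- compound 3 `C/C=C\c1nc(CC/C=C\C(=O)O[C@H]2C[C@@H]3CC(=O)O[C@@H](CCC)C[C@@H](OC)C/C(C)=C\[C@H](C2)O3)co1`: 740 nM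

Compound 3, at 740 nM, lies within the scatter of compound 1, at 500 nM, and far from compound 2, at 0.5 nM.

Compound 4 `CCC[C@H]1C[C@@H](OC)C/C(C)=C\[C@@H]2C[C@@H](OC(=O)/C=C\CCc3coc(C=C(C)C)n3)C[C@H](CC(=O)O1)O2` is still to be measured in this assay. It departs from compound 3 by one change: 2-methylprop-1-en-1-yl in place of prop-1-en-1-yl on an aromatic carbon. In words, 2-methylprop-1-en-1-yl stands in place of prop-1-en-1-yl on an aromatic carbon.

Among the measured compounds shown here, the only measured step in this part of the molecule is a 1500-fold higher number from compound 2 to compound 3 (3.17 log units; beyond the scatter), with hydrogen in place of (methoxycarbonyl)amino. That large step does not test the new change, but compound 4 also lacks (methoxycarbonyl)amino, so compound 3 at 740 nM is the natural reference. For the measured compounds named here, no measured step replaces prop-1-en-1-yl, so no shift beyond the scatter is expected, though this rests on thin evidence.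

The estimated change is a 1.2-fold lower number from compound 3 to compound 4 (0.09 log units; within the scatter). For compound 4 the expected value is 600 nM, with an estimated range of 130 nM to 2800 nM.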

Compound 4, half-maximal inhibitory concentration: 3900 nM
Beside the measured number, compound 4's estimate is 6.5-fold (0.81 log units) below it; measured number outside the range, above it.
By their numbers in this assay, from the lowest: compound 2; then compounds 1 and 3 (each within the scatter of the next); then compound 4.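

In this assay this aromatic carbon proves sensitive to the alkenyl group itself: 2-methylprop-1-en-1-yl in place of prop-1-en-1-yl gives a 5.3-fold higher number from compound 3 to compound 4 (0.72 log units; beyond the scatter), so one extra carbon, with no hydrogen-bond donor or acceptor entering, does not leave the number unchanged. The earlier step at this position only removed (methoxycarbonyl)amino. Against the full 3-((methoxycarbonyl)amino)prop-1-en-1-yl group, 2-methylprop-1-en-1-yl gives a 7800-fold higher number from compound 2 to compound 4 (3.89 log units; beyond the scatter), a large step beside the modest one between the two short alkenyl groups.

Still open, from the compounds shown here alone, is how a saturated propyl chain, or an amine or a carboxylic acid at the end of the prop-1-en-1-yl chain, would read at this carbon. Nothing measured here accounts for the higher number of compound 4.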